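The compounds below may be only part of what the source reports. "The series", "measured", "known", "first", "only" and "open" are said of these compounds alone.

Measured so far:
- compound 1 `Nc1ccccc1NC(=O)/C=C/c1ccc(CSc2ccc(Cl)cc2)cc1` gives 55.3%
- compound 2 `CCc1ccc(SCc2ccc(/C=C/C(=O)Nc3ccccc3N)cc2)cc1` gives 60.7%

In a functional assay on A549 cells (Homo sapiens) for inhibition, read by CCK-8 assay, with a stated time of 72 h, tested at 2 uM (on this read-out higher numbers stand for more inhibition of growth at the one concentration tested and lower numbers for less inhibition of growth), compound 2 at 60.7% stands level, within the scatter, with compound 1 (at 55.3%). Compound 3 `Nc1ccccc1NC(=O)/C=C/c1ccc(CSc2ccc(C(F)(F)F)cn2)cc1` departs from compound 2 by one change (5-(trifluoromethyl)pyridin-2-yl in place of 4-ethylphenyl on a sulfur). Among the measured compounds shown here, the only measured step bearing on it is a number 5.4 percentage points higher from compound 1 to compound 2 (within the scatter) and that step, ethyl in place of chloro on an aromatic carbon, keeps the ring itself. For the measured compounds named here, no measured step replaces that ring, so nothing beyond the scatter is expected in this assay and the expected step is small (a number 4.7 percentage points lower from compound 2 to compound 3 (within the scatter)). The estimate for compound 3 is 56% with an expected range (40% to 70%).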

Compound 3, percent growth inhibition at one concentration: 51.7%
The estimate for compound 3 lay 4.3 percentage points above the measured number; low and high end bracket the measured number.
By their numbers in this assay, from the lowest: compounds 3, 1 and 2 (each within the scatter of the next).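

In this assay the whole aromatic group on the sulfur has now been exchanged, not only its substituent: 5-(trifluoromethyl)pyridin-2-yl in place of 4-ethylphenyl (a number 9 percentage points lower from compound 2 to compound 3 (within the scatter)) and in place of 4-chlorophenyl (a number 3.6 percentage points lower from compound 1 to compound 3 (within the scatter)). Neither exchange, which brings in a ring hetero atom and a hydrogen-bond acceptor, moves the number beyond the scatter. No measured evidence bears on this result. 

Still open, going by these compounds, is whether the sulfur needs an aromatic group at all, since a cyclohexyl group or a carboxylic acid on a short chain would test this.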